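From a Benzyl Amide to an Anilide

A few compounds are considered here, and "the series" means these few. Any claim that something is new, unique, unknown or untested is made for them only; others in the source may bear on it.

Measured so far:
Compound 1 `COc1ccc2c(=O)c(/C=C/C(=O)NCc3cccc(F)c3)coc2c1` gives 17600 nM in a functional assay on HeLa cells (Homo sapiens) for inhibition, read by MTT assay, with a stated time of 48 h; on this read-out lower numbers stand for stronger inhibition and higher numbers for weaker inhibition.
Compound 2 `Cc1ccc(CNC(=O)/C=C/c2coc3cc(O)ccc3c2=O)cc1` gives only a limit of this assay, reported as > 100000 nM.

Compound 1 holds the only number in this set; the other entry is a limit, as shown by the limit of > 100000 nM in this assay, at which 1 of the 2 values shown sits. Compound 3 `COc1ccc2c(=O)c(/C=C/C(=O)Nc3ccccc3OC)coc2c1` differs from compound 1 in one place: 2-methoxyphenyl in place of 3-fluorobenzyl on an amide-type nitrogen. For the measured compounds named here, no step between measured compounds is available, so the weight of this change cannot be read from the set. The step of a 1.6-fold higher number from compound 1 to compound 3 (0.20 log units; within the scatter) is expected to be modest, leaning toward weaker inhibition but not clearly beyond the usual scatter. Compound 3 is estimated at 28000 nM, within 7000 nM to 100000 nM.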

Compound 3, half-maximal inhibitory concentration: > 100000 nM
Compound 3 was reported as a limit; the forecaster's own chance of this, stated with the estimate: 25%; middle value at least 3.5-fold (0.55 log units) from the limit.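

In this assay, 2-methoxyphenyl in place of 3-fluorobenzyl on the amide-type nitrogen gives an at least 5.6-fold higher number from compound 1 to compound 3 (0.75 log units; beyond the scatter), the first step the set allows, and it shows that this position does not tolerate every aromatic group equally. The entry for compound 3, > 100000 nM, is a limit and not a number. Only compound 1 keeps a measured value: the limit of > 100000 nM in this assay, at which 2 of the 3 values shown sit.

The step joins two differences, the loss of the benzyl carbon and the exchange of fluorine for methoxy, and the compounds shown do not separate them. A 2-methoxybenzyl or 3-fluorophenyl group on the same nitrogen would do so.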